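Series notes: aryl for aryloxy, compound 3 to compound 4

This account rests on a few compounds, and the source may have more. Where it says the series, first, only, none or still open, it means among the compounds named here.

Three compounds of the series have numbers in an ADME assay on HepG2 cells (Homo sapiens) for cytotoxicity, read by luminescence, CellTiter-Glo and ATP content, with a stated time of 72 h; on this read-out higher numbers stand for an effect only at larger amounts of compound and lower numbers for an effect already at smaller amounts. Compound 3 `COc1ccccc1Oc1ccc2c(NCCCNCc3cccc(OC)c3O)ccnc2c1` gives 11200 nM and stands highest of the three. Compound 1 `COc1ccc(Oc2ccc3c(NCCCNCc4cccc(OC)c4O)ccnc3c2)cc1` gives 5500 nM in this assay, and compound 2 `COc1cccc(CNCCCNc2ccnc3cc(-c4ccccc4)ccc23)c1O` gives 3210 nM. Between compound 1 and compound 3 the step is a 2.0-fold higher number from compound 1 to compound 3 (0.31 log units; beyond the scatter).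

Compound 4 `COc1cccc(CNCCCNc2ccnc3cc(-c4ccc(C(F)(F)F)cc4)ccc23)c1O` is not yet measured in this assay. It differs from compound 3 in one place: 4-(trifluoromethyl)phenyl in place of 2-methoxyphenoxy on an aromatic carbon. For the measured compounds named here, two measured steps bear on this exchange of an aryloxy group for a directly attached aryl group. Going the other way, a 3.5-fold higher number from compound 2 to compound 3 (0.54 log units; beyond the scatter), and a 1.7-fold lower number from compound 1 to compound 2 (0.23 log units; within the scatter). Removal of the oxygen link therefore points to a lower number for compound 4 than for compound 3, of modest size, while the trifluoromethyl group has no precedent in the series and widens the range. For compound 4 the expected value in this assay is 4000 nM, with a range from 1800 nM to 9000 nM. The step this estimate implies is a 2.8-fold lower number from compound 3 to compound 4 (0.45 log units; beyond the scatter).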

Compound 4, half-maximal effective concentration: 2210 nM
The estimate for compound 4 lay 1.8-fold (0.26 log units) above the measured number; the range from low to high includes it.
By their numbers in this assay, from the lowest: compounds 4, 2 and 1 (each within the scatter of the next, the first and the last beyond it); then compound 3.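

Compound 2 and compound 4 are not separated (a 1.5-fold lower number from compound 2 to compound 4 (0.16 log units; within the scatter)), so at this position in this assay, trifluoromethyl on the directly attached phenyl group gives no step beyond the scatter. The aryl-for-aryloxy exchange now clears the scatter against both aryloxy compounds (a 5.1-fold lower number from compound 3 to compound 4 (0.70 log units; beyond the scatter); a 2.5-fold lower number from compound 1 to compound 4 (0.40 log units; beyond the scatter)), whereas the unsubstituted phenyl group of compound 2 did so only against compound 3, so the earlier contrast with compound 1 is sharper for this aryl group. Nothing available here gives a cause for these steps.

Open, as far as these compounds go, is whether a carboxylic acid or an amine on the same phenyl group would leave the number unchanged, as trifluoromethyl does. Also open, from the compounds shown here alone, is whether trifluoromethyl on the phenyl ring of an aryloxy group would give the same result.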